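The source may hold more compounds than are shown below. What is called first, only, known or untested is meant among the compounds shown, and "the series" means these compounds.

Compound 1 `COc1ccccc1-n1nncc1CN1C(=O)C2(C(C#N)=C(N)Oc3c(N)cc4nc5ccccc5nc4c32)c2ccccc21` gives 28900 nM in a functional assay on MCF7 cells (Homo sapiens) for antiproliferative activity, read by MTT assay, with a stated time of 48 h; a lower number here means a stronger inhibitor, a higher number a weaker inhibitor.
Compound 2 `CCOc1ccccc1-n1nncc1CN1C(=O)C2(C(C#N)=C(N)Oc3c(N)cc4nc5ccccc5nc4c32)c2ccccc21` gives > 50000 nM in this assay, which is a limit of the assay and not a number.
Compound 3 `Cc1ccc(-n2nncc2CN2C(=O)C3(C(C#N)=C(N)Oc4c(N)cc5nc6ccccc6nc5c43)c3ccccc32)cc1Cl` gives > 50000 nM in this assay, likewise a limit.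

Compound 3 thus stands at the limit, as does compound 2 (the limit of > 50000 nM in this assay, at which 2 of the 3 values shown sit), and only compound 1 has a measured number. The change to compound 4 `Cc1ccc(Cl)cc1-n1nncc1CN1C(=O)C2(C(C#N)=C(N)Oc3c(N)cc4nc5ccccc5nc4c32)c2ccccc21` is 5-chloro-2-methylphenyl in place of 3-chloro-4-methylphenyl on an aromatic nitrogen. Going by the values given here, the measured steps that reach compound 3 are an at least 1.7-fold higher number from compound 1 to compound 3 (0.23 log units; that floor lies within the scatter) and a step that the two limits leave unreadable from compound 2 to compound 3; neither has a readable size, and no measured step rearranges the chlorine and methyl of this group. Compound 4 is therefore expected to remain near the limit, with a number no higher from compound 3 to compound 4 (the limit leaves the size open) as the estimated step, none beyond the scatter. Compound 4 is estimated at 50000 nM, in a range from 15000 nM to 150000 nM.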

Compound 4, half-maximal inhibitory concentration: 43500 nM
For compound 4 the middle estimate is 1.1-fold (0.06 log units) above the measured one, and the stated range covers the measured number.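

Across the compounds shown, the aromatic nitrogen tolerates this rearrangement of chlorine and methyl in this assay, and 5-chloro-2-methylphenyl gives a readable number: the change is an at least 1.1-fold lower number from compound 3 to compound 4 (0.06 log units; that floor lies within the scatter), and the change from the ethoxy compound is an at least 1.1-fold lower number from compound 2 to compound 4 (0.06 log units; that floor lies within the scatter). Against the methoxy compound, 5-chloro-2-methylphenyl shows a 1.5-fold higher number from compound 1 to compound 4 (0.18 log units; within the scatter), so these two groups cannot be told apart here. The first two steps are floors only, set by a limit of the assay: the limit of > 50000 nM in this assay, at which 2 of the 4 values shown sit.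

Going by these compounds, what an amine or a carboxylic acid on this phenyl ring would do to the number stays open. So does the effect of a longer alkoxy chain in place of the methoxy group of compound 1.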